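Adding a Bromo Group to Compound 1

The source may hold more compounds than are shown below. What is called first, only, known or untested is meant among the compounds shown, and "the series" means these compounds.

In a functional assay on S2 cells (Drosophila melanogaster) for cytotoxicity, read by MTT assay, with a stated time of 24 h (on this read-out lower numbers stand for stronger inhibition and higher numbers for weaker inhibition), compound 1 (`O=C1CC(c2ccccc2)Nc2ccccc21`) gives 4000 nM and compound 2 (`O=C1CC(c2ccc(O)cc2O)Nc2ccccc21`) gives 4000 nM so the two stand level, and compound 1 has no measured neighbour above or below it. Compound 3 (`O=C1CC(c2ccc(Br)cc2)Nc2ccccc21`) follows from compound 1 by one change, with bromo in place of hydrogen on an aromatic carbon of a six-membered aromatic ring of carbon only, para to a large group (bromo in place of hydrogen on an aromatic carbon). Among the compounds with values here, no measured pair differing in one place shows what such a change does here, so the expectation is cautious. A slight shift towards stronger inhibition is expected in this assay but none beyond the scatter. The estimated step (a 1.3-fold lower number from compound 1 to compound 3 (0.12 log units; within the scatter)) is therefore small. For compound 3 the estimated value is 3000 nM with an expected range from 1200 nM to 7000 nM in this read-out.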

Compound 3, half-maximal inhibitory concentration: 4000 nM
For compound 3 the middle estimate is 1.3-fold (0.12 log units) below the measured one; the measured number falls inside the stated range.
By their numbers in this assay, from the lowest: compounds 1, 2 and 3 (each within the scatter of the next).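

In this assay, replacing hydrogen with bromo on this aromatic carbon, para to a large group, gives no change at the digits printed from compound 1 to compound 3 (within the scatter). Within the data shown here, this is the first step that differs in one place only, and it shows that a single bromine atom can stand at this position with no shift in the read-out beyond the scatter. Nothing at hand gives a measured property of the bromo group or accounts for this outcome.

From the compounds shown here alone, whether other groups at this position would read the same remains open, as a methoxy group, an amine or a carboxylic acid could each behave differently from bromo. Going by these compounds, it is equally open whether a longer chain in place of the bromo group would leave the number unchanged.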